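A few compounds are considered here, and "the series" means these few. Any claim that something is new, unique, unknown or untested is made for them only; others in the source may bear on it.

Working notes on the series. Compound 1 `CN(C(=O)NC(=O)c1c(F)cccc1F)c1nc(C(F)(F)F)c(C(=O)N/N=C/c2cccc(C(F)(F)F)c2)s1` carries the shared core; in an ADME assay on L02 cells (Homo sapiens) for inhibition, read by MTT assay, with a stated time of 72 h (on this read-out higher numbers stand for weaker inhibition and lower numbers for stronger inhibition), compound 1 gives "not determined" (no result reported), so no number is available for it. Within the data shown here, compound 2 `CN(C(=O)NC(=O)c1ccc(F)c(F)c1)c1nc(C(F)(F)F)c(C(=O)N/N=C/c2cc(C(F)(F)F)cc(C(F)(F)F)c2)s1` is the one compound with a number in this assay: compound 2 gives 20.1 ug/mL. On the numbers shown, compound 2 therefore stands alone; no other value stands beside it, and no step between measured compounds can be drawn from the data.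

Compound 3 `CN(C(=O)NC(=O)c1ccc(F)c(F)c1)c1nc(C(F)(F)F)c(C(=O)N/N=C/c2cccc(C(F)(F)F)c2)s1` has not been measured in this assay. It differs from compound 2 by hydrogen in place of trifluoromethyl on an aromatic carbon. Among the measured compounds shown here, no step between measured compounds shows what this change does in this assay, and the value of compound 1 gives no help. For the measured compounds named here, with nothing to lean on but the single value of compound 2, the expectation is that the step of a 1.2-fold higher number from compound 2 to compound 3 (0.09 log units; within the scatter) stays within the usual scatter, with no direction beyond it. Compound 3 is accordingly estimated at 25 ug/mL in this assay, with a range of 10 ug/mL to 60 ug/mL.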

Compound 3, half-maximal inhibitory concentration: 23.5 ug/mL
Compound 3: middle estimate off by 1.1-fold (0.03 log units), on the high side; low and high end bracket the measured number.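

In this assay, among these compounds, this pair gives the first readable step for this position, a 1.2-fold higher number from compound 2 to compound 3 (0.07 log units; within the scatter) and the change is hydrogen in place of trifluoromethyl on an aromatic carbon. The other trifluoromethyl group of compound 2 remains in compound 3 and takes no part in the comparison. The two compounds are therefore not separated on this read-out, and on this single pair the ring carries one trifluoromethyl group or two with no difference beyond the scatter. No measured evidence bears on why the two numbers lie so close.

Going by these compounds, what a larger or differently built group would do on this aromatic carbon remains open: a pair with an amine, a carboxylic acid or a longer chain there could show whether the position stays as undemanding as this one pair suggests. Among the compounds shown here, also open are hydrogen in place of the remaining trifluoromethyl group and the arrangement of the two fluorine atoms, which compound 1 holds differently from compound 3, since the single step here speaks to neither.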